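Sulfone for Ether on the Pyridyl Core

The source may hold more compounds than are shown below. What is called first, only, known or untested is meant among the compounds shown, and "the series" means these compounds.

Compound 1 `CCC(CC)CNc1c(C(N)=O)cnc2ccc(-c3ccc(COC)cc3)cc12` gives 76 uL/min in an ADME assay on cells (Hepatocyte, Rattus norvegicus) for metabolic stability, with a stated time of 90 min; on this read-out lower numbers stand for slow clearance and higher numbers for fast clearance. Compound 2 `CCC(CC)CNc1c(C(N)=O)cnc2ccc(-c3ccc(CS(C)(=O)=O)cc3)cc12` carries methylsulfonyl in place of methoxy on a saturated chain carbon bound to an aromatic carbon and gives 210 uL/min in this assay, a step of a 2.8-fold higher number from compound 1 to compound 2 (0.44 log units; beyond the scatter). Compound 3 `CCC(CC)CNc1c(C(N)=O)cnc2ccc(-c3ccc(COC)nc3)cc12` differs from compound 1 by 6-(methoxymethyl)pyridin-3-yl in place of 4-(methoxymethyl)phenyl on an aromatic carbon. Compound 3 gives 110 uL/min in this assay, a step of a 1.4-fold higher number from compound 1 to compound 3 (0.16 log units; within the scatter). Compound 4 `CCC(CC)CNc1c(C(N)=O)cnc2ccc(-c3ccc(CS(C)(=O)=O)nc3)cc12` has not been measured; it differs from compound 3 by methylsulfonyl in place of methoxy on a saturated chain carbon bound to an aromatic carbon, the same change as that from compound 1 to compound 2, made at the same place on the core of compound 3. The step of a 2.6-fold higher number from compound 3 to compound 4 (0.42 log units; beyond the scatter) is expected because the same change gave a 2.8-fold higher number from compound 1 to compound 2 (0.44 log units; beyond the scatter). In this assay compound 4 is estimated at 290 uL/min, with a range from 150 uL/min to 550 uL/min.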

Compound 4, intrinsic clearance in a liver preparation (reported as CLH), per the amount of preparation that the assay uses: 200 uL/min
Compound 4: middle estimate off by 1.5-fold (0.16 log units), on the high side; low and high end bracket the measured number.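

In this assay, methylsulfonyl in place of methoxy on the second core gives a 1.8-fold higher number from compound 3 to compound 4 (0.26 log units; within the scatter), so on this core the change does not clearly separate the two compounds. Set beside the step on the first core, the two results do not differ: the same change on two cores in this assay, a 2.8-fold higher number (0.44 log units; beyond the scatter) from compound 1 to compound 2 and a 1.8-fold higher number (0.26 log units; within the scatter) from compound 3 to compound 4, 1.5-fold (0.18 log units) apart, within the scatter of two such steps. This is consistent with the change carrying over between these two cores, but a single pair of cores cannot show that it holds generally, nor does it fix the size of the step on the second core.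

The compounds shown leave open how an amine, a carboxylic acid or a longer chain would behave at this place. They also leave open whether the change carries over to any further core.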